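A few compounds are considered here, and "the series" means these few. Any claim that something is new, unique, unknown or untested is made for them only; others in the source may bear on it.

Compound 1 `COc1nc2ccc(Br)cc2cc1C(c1ccccc1)n1cc(-c2cccc(F)c2)nn1` gives 15.5% in an ADME assay on PANC-1 cells (Homo sapiens) for cytotoxicity, read by sulforhodamine B assay, with a stated time of 48 h, tested at 10 uM; a higher number here means more inhibition at the concentration tested (going by the name of the read-out), a lower number less inhibition.
Compound 2 `COc1nc2ccc(Br)cc2cc1C(c1ccccc1)n1cc(-c2ccc(OC(F)(F)F)cc2)nn1` gives 11.7% in this assay.
Compound 3 `COc1nc2ccc(Br)cc2cc1C(c1ccccc1)n1cc(-c2ccccc2)nn1` gives 30.1% in this assay.

Compound 3 stands highest of the three measured numbers, since a number 14.6 percentage points higher from compound 1 to compound 3 (beyond the scatter) and a number 18.4 percentage points higher from compound 2 to compound 3 (beyond the scatter) both lie beyond the scatter, while a number 3.8 percentage points lower from compound 1 to compound 2 (within the scatter) lies within it. Compound 4 `COc1nc2ccc(Br)cc2cc1C(c1ccccc1)n1cc(-c2ccccc2C(F)(F)F)nn1` differs from compound 3 by trifluoromethyl in place of hydrogen on an aromatic carbon. The two steps that bear on it, a number 14.6 percentage points higher from compound 1 to compound 3 (beyond the scatter) and a number 18.4 percentage points higher from compound 2 to compound 3 (beyond the scatter), both show that the unsubstituted ring of compound 3 sits above its substituted relatives by a modest margin. Among the measured compounds shown here, putting a group back onto that ring is therefore expected to move the number down by a modest amount, a number 13.1 percentage points lower from compound 3 to compound 4 (beyond the scatter), though no step tests this particular place. Compound 4 is estimated at 17%, within 4% to 32%.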

Compound 4, a percentage reported as inhibition, at one concentration (the size of the read-out at that concentration, not a potency): 11.4%
The estimate for compound 4 lay 5.6 percentage points above the measured number; the measured number falls inside the stated range.
By their numbers in this assay, from the lowest: compounds 4, 2 and 1 (each within the scatter of the next); then compound 3.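

In this assay, among the compounds shown here, trifluoromethyl on the aromatic carbon ortho to a large group gives a number 18.7 percentage points lower from compound 3 to compound 4 (beyond the scatter), a modest fall at a ring place the earlier compounds did not cover. The other two steps, a number 0.3 percentage points lower from compound 2 to compound 4 (within the scatter) and a number 4.1 percentage points lower from compound 1 to compound 4 (within the scatter), show that all three substituted rings read alike, so all lie under the unsubstituted ring of compound 3 and this assay does not separate them. Nothing available explains the fall.

Going by these compounds, whether a methyl group, an amine or a carboxylic acid at this place would also lower the number remains open.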